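The compounds below may be only part of what the source reports. "The series", "measured", "known", "first", "only" and "open" are said of these compounds alone.

Measured in an ADME assay on cells (Fibroblast, Gallus gallus) for cytotoxicity, read by CCK-8 assay, with a stated time of 48 h; on this read-out higher numbers stand for lower toxicity in this test and lower numbers for higher toxicity in this test:
Compound 1 `CCC(CC)O[C@@H]1C=C(C(=O)O)C[C@H](NCc2ccc(OC)cc2)[C@H]1NC(C)=O`: > 200000 nM
Compound 2 `CCC(CC)O[C@@H]1C=C(C(=O)O)C[C@H](NCc2ccc(SCC(C)C)cc2)[C@H]1NC(C)=O`: > 200000 nM
Compound 3 `CCC(CC)O[C@@H]1C=C(C(=O)O)C[C@H](NCc2ccc(SC(C)CC)cc2)[C@H]1NC(C)=O`: > 200000 nM

Each of these entries is a limit of the assay and not a number. Compound 3 therefore has no position of its own among the three, and the picture is the limit of > 200000 nM in this assay, at which 3 of the 3 values shown sit.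

The next compound, compound 4 `CCC(CC)O[C@@H]1C=C(C(=O)O)C[C@H](NCc2ccc(-c3ccc(SC)cc3)cc2)[C@H]1NC(C)=O`, changes one group on an aromatic carbon: 4-(methylsulfanyl)phenyl in place of (sec-butyl)sulfanyl on an aromatic carbon. Here 4-(methylsulfanyl)phenyl takes the place of (sec-butyl)sulfanyl.

Three measured steps changed a group at this place: a step that the two limits leave unreadable from compound 1 to compound 2, a step that the two limits leave unreadable from compound 1 to compound 3 and a step that the two limits leave unreadable from compound 2 to compound 3. None of them has a readable size, and none brought in a further aromatic ring. Going by the values given here, no step of a definite size or direction can be drawn from them for this assay.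

The expectation rests on compound 3, whose limit is > 200000 nM. Another reading at the limit is thought most likely, with some room for a lower number.

The estimated step is a number no higher from compound 3 to compound 4 (the limit leaves the size open). For compound 4 the expected value is 200000 nM, with an estimated range from 60000 nM to 400000 nM.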

Compound 4, half-maximal cytotoxic concentration: > 200000 nM
Compound 4 ended at the assay's limit; the forecaster's own chance of this, stated with the estimate: 65%; the middle value sits exactly at the limit.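

Compound 4 gives > 200000 nM, a limit of the assay and not a number. The steps to compound 4 from compound 1, compound 2 and compound 3 therefore cannot be read in this assay: the limit of > 200000 nM in this assay, at which 4 of the 4 values shown sit. The compounds shown leave open how these four compounds rank in this test.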